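Chloroanilide thioesters tested for growth inhibition

A few compounds are considered here, and "the series" means these few. Any claim that something is new, unique, unknown or untested is made for them only; others in the source may bear on it.

Measured compounds:
compound 1, `CC(=O)SCCC(CCCCC(=O)Nc1cccc(Cl)c1)SC(C)=O`, 0.31%
compound 2, `CC(=O)SCCC(CCCCC(=O)Nc1ccc(Cl)cc1)SC(C)=O`, 15.4%
compound 3, `O=C(CCCCC(CCSC(=O)c1ccccc1)SC(=O)c1ccccc1)Nc1cccc(Cl)c1`, 9.48%

The three measured compounds were tested in a functional assay on NCI-H460 cells (Homo sapiens) for inhibition, read by MTT assay, with a stated time of 24 h, tested at 1 ug/mL; on this read-out lower numbers stand for less inhibition of growth and higher numbers for more inhibition of growth at the one concentration tested. Compound 1 `CC(=O)SCCC(CCCCC(=O)Nc1cccc(Cl)c1)SC(C)=O` gives 0.31% in this assay, compound 2 `CC(=O)SCCC(CCCCC(=O)Nc1ccc(Cl)cc1)SC(C)=O` gives 15.4%, and compound 3 `O=C(CCCCC(CCSC(=O)c1ccccc1)SC(=O)c1ccccc1)Nc1cccc(Cl)c1` gives 9.48%. Compound 1 and compound 2 differ by one change, (4-chlorophenyl in place of 3-chlorophenyl on an amide-type nitrogen), and this change made a step of a number 15.1 percentage points higher from compound 1 to compound 2 (beyond the scatter). The difference between the core of compound 1 and the core of compound 3 is not broken down here; the two values simply show that compound 3 and compound 1 lie within the scatter of each other.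

Compound 4 `O=C(CCCCC(CCSC(=O)c1ccccc1)SC(=O)c1ccccc1)Nc1ccc(Cl)cc1` has not yet been measured. It differs from compound 3 by 4-chlorophenyl in place of 3-chlorophenyl on an amide-type nitrogen, the same change as from compound 1 to compound 2, at the same place on an amide-type nitrogen. Within the data shown here, the earlier change, a number 15.1 percentage points higher from compound 1 to compound 2 (beyond the scatter), is the only precedent. Compound 4 is therefore expected to show a step of about a number 14.5 percentage points higher from compound 3 to compound 4 (beyond the scatter) from compound 3, resting on that one earlier step. The estimate for compound 4 is 24%, with the likely range 6% to 42%.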

Compound 4, percent growth inhibition at one concentration: 9.8%
Compound 4: the middle estimate sits 14.2 percentage points above what was measured; measured number inside the range.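

In this assay, placing 4-chlorophenyl where 3-chlorophenyl stood on the amide-type nitrogen gave a number 0.3 percentage points higher from compound 3 to compound 4 (within the scatter), so on the core of compound 3 the change produced no readable difference. Set beside the earlier step, the change did not carry over from one core to the other with the same size: the same change on two cores in this assay, a number 15.1 percentage points higher (beyond the scatter) from compound 1 to compound 2 and a number 0.3 percentage points higher (within the scatter) from compound 3 to compound 4, 14.8 percentage points apart, beyond the scatter of two such steps. Among these compounds, this shows that the step seen on the core of compound 1 cannot be treated as a fixed increment for this change, but it rests on only two steps at a single concentration and does not show why the two cores differ or how the change would behave on a further core.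

The compounds shown leave open whether the two cores would also part ways with a bromine or a methoxy group in place of the chlorine. Also open, from the compounds shown here alone, is how the same change would read with free thiols in place of the thioesters, or with a longer chain.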